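A morpholine amide in place of a pyrrolidine amide

This account rests on a few compounds, and the source may have more. Where it says the series, first, only, none or still open, it means among the compounds named here.

Compound 2 `Cn1c(/C=C2\SC(=O)N(CC(=O)N3CCCC3)C2=O)nc2ccccc21` carries the shared core with a pyrrolidin-1-yl group on the carbonyl carbon. In a functional assay on PC-3 cells (Homo sapiens) for inhibition, read by MTT assay, with a stated time of 48 h (a higher number here means a weaker inhibitor, a lower number a stronger inhibitor), compound 2 gives > 50000 nM, which is a limit of the assay and not a number. Within the data shown here, compound 1 `Cn1c(/C=C2\SC(=O)N(CC(=O)Nc3cc(C(C)(C)C)on3)C2=O)nc2ccccc21` is the only other compound measured. In this assay compound 1 gives > 50000 nM, likewise a limit. The step that the two limits leave unreadable from compound 1 to compound 2 cannot be read from these two values; the evidence the limit of > 50000 nM in this assay, at which 2 of the 2 values shown sit, is all that they show. Compound 3 `CC1CN(C(=O)CN2C(=O)S/C(=C\c3nc4ccccc4n3C)C2=O)CC(C)O1` differs from compound 2 in one place: 2,6-dimethylmorpholin-4-yl in place of pyrrolidin-1-yl on a carbonyl carbon. Among the measured compounds shown here, no measured step bears on this change in a readable way; the one step known ends at the limit on both sides. Compound 3 is therefore expected to sit near the same limit in this assay. The step of a number no higher from compound 2 to compound 3 (the limit leaves the size open) is expected to be no step beyond the scatter. The estimate for compound 3 in this assay is 50000 nM, between 20000 nM and 120000 nM, and it is expected most likely to be reported again as a limit rather than a number.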

Compound 3, half-maximal inhibitory concentration: > 50000 nM
Compound 3 was reported as a limit; the forecaster's own chance of this, stated with the estimate: 80%; the middle value lies on the limit itself.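

In this assay compound 3 gives > 50000 nM, which is a limit of the assay and not a number. Among these compounds, no step from compound 2 or compound 1 to compound 3 can be read. The compounds shown leave open whether any group on that carbonyl carbon brings the shared core to a readable number, since all three rest on one limit: the limit of > 50000 nM in this assay, at which 3 of the 3 values shown sit.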